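The source may report more compounds than this note shows. Statements on the series, on what has been measured and on what is new or still open speak of the compounds shown alone.

Working notes on the series, all compounds sharing one core. In an ADME assay on L6 cells (Rattus norvegicus) for cytotoxicity, read by resazurin assay, with a stated time of 72 h (a lower number here means a stronger inhibitor, a higher number a weaker inhibitor), compound 1 `NC1CC2(N3CCCC3)CC(c3ccccc3)C1C(c1ccccc1)C2` gives 38100 nM, compound 2 `CN1CCN(CC(=O)OC2CC3(N4CCCC4)CC(c4ccccc4)C2C(c2ccccc2)C3)CC1` gives 24600 nM and compound 3 `CCN(CC)CC(=O)OC1CC2(N3CCCC3)CC(c3ccccc3)C1C(c1ccccc1)C2` gives 49000 nM. Compound 3 therefore sits level with the other two, since neither step that reaches it goes beyond the scatter.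

Next is compound 4 `O=C(CN1CCCCC1)OC1CC2(N3CCCC3)CC(c3ccccc3)C1C(c1ccccc1)C2`, with piperidin-1-yl in place of diethylamino on a saturated chain carbon bound to a carbonyl carbon. The closest measured change lies at that same place, a 2.0-fold higher number from compound 2 to compound 3 (0.30 log units; within the scatter). The two exchanges on a saturated ring carbon, a 1.5-fold lower number from compound 1 to compound 2 (0.19 log units; within the scatter) and a 1.3-fold higher number from compound 1 to compound 3 (0.11 log units; within the scatter), also stayed within the scatter. Among the compounds with values here, no measured compound carries piperidin-1-yl at this place, so the effect of this exact exchange is unknown.

With all three measured steps this small, no step beyond the scatter is expected in this assay, and the direction is only weakly indicated, towards the middle of the three measured values. The estimate amounts to a 1.4-fold lower number from compound 3 to compound 4 (0.13 log units; within the scatter), which is expected to remain within the scatter. For compound 4 the estimated value is 36000 nM, with an expected range of 20000 nM to 65000 nM.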

Compound 4, half-maximal inhibitory concentration: 14200 nM
Beside the measured number, compound 4's estimate is 2.5-fold (0.40 log units) above it, and the stated range ends above it.
By their numbers in this assay, from the lowest: compounds 4, 2, 1 and 3 (each within the scatter of the next, the first and the last beyond it).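

In this assay, the place on a saturated chain carbon bound to a carbonyl carbon now gives a step beyond the scatter, a 3.5-fold lower number from compound 3 to compound 4 (0.54 log units; beyond the scatter), where the step from 4-methylpiperazin-1-yl to diethylamino had not left it. Within the data shown here, the exchange on a saturated ring carbon also passes the scatter for the first time with (((piperidin-1-yl)methyl)carbonyl)oxy in place of amino, a 2.7-fold lower number from compound 1 to compound 4 (0.43 log units; beyond the scatter), so this side chain separates from the amino compound where the other two did not. Having a ring at this place does not by itself mark a separate group of compounds: piperidin-1-yl stays within the scatter of 4-methylpiperazin-1-yl, a 1.7-fold lower number from compound 2 to compound 4 (0.24 log units; within the scatter), and 4-methylpiperazin-1-yl stays within the scatter of the open diethylamino.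

The compounds shown leave open whether another ring amine such as morpholin-4-yl, or a smaller open amine such as dimethylamino, would follow piperidin-1-yl or diethylamino at this place. Nothing available here bears on what lies behind this difference in cytotoxicity.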